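Swapping a benzimidazole for a formyl-methoxyphenoxy group

A few compounds are considered here, and "the series" means these few. Any claim that something is new, unique, unknown or untested is made for them only; others in the source may bear on it.

Measured compounds:
compound 1 `CCOC(=O)c1c(-c2ccccc2)nn(-c2ccccc2)c1Cn1c(Cl)nc2ccccc21`: 10 ug/mL
compound 2 `CCOC(=O)c1c(-c2ccccc2)nn(-c2ccccc2)c1COc1cc(OC)c(C=O)c(OC)c1`: 40 ug/mL
compound 3 `CCOC(=O)c1c(-c2ccccc2)nn(-c2ccccc2)c1Cn1cnc2cc(C)ccc21`: 45 ug/mL

In an assay for inhibition of Alpha amylase (Homo sapiens), with a stated time of 30 min (on this read-out higher numbers stand for weaker inhibition and lower numbers for stronger inhibition), compound 3 gives 45 ug/mL, the highest of the three numbers. Its nearest neighbour is compound 2, which gives 40 ug/mL, a value within the scatter of compound 3; the furthest is compound 1 at 10 ug/mL. Going by the values given here, the only measured step in this set is a 4.5-fold higher number from compound 1 to compound 3 (0.65 log units; beyond the scatter), and it concerns an exchange of one benzimidazole for another on the shared core, not the change now at hand.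

Compound 4 `CCOC(=O)c1c(-c2ccccc2)nn(-c2ccccc2)c1COc1ccc(C=O)cc1OC` is not yet measured. Its difference from compound 3 is 4-formyl-2-methoxyphenoxy in place of 5-methyl-1H-benzimidazol-1-yl on a saturated chain carbon bound to an aromatic carbon. Among the compounds with values here, no measured step covers this exchange directly, but compound 2 already carries a methoxy- and formyl-bearing phenoxy group on the same carbon and sits within the scatter of compound 3. Compound 4 is therefore expected to give 40 ug/mL (range 20 ug/mL to 80 ug/mL), a step of a 1.1-fold lower number from compound 3 to compound 4 (0.05 log units; within the scatter) that is expected to stay within the scatter.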

Compound 4, half-maximal inhibitory concentration: 60 ug/mL
Compound 4: the middle estimate sits 1.5-fold (0.18 log units) below what was measured; measured number inside the range.
By their numbers in this assay, from the lowest: compound 1; then compounds 2, 3 and 4 (each within the scatter of the next).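

In this assay, the step of a 1.3-fold higher number from compound 3 to compound 4 (0.12 log units; within the scatter) stays within the scatter, so on a saturated chain carbon bound to an aromatic carbon, 4-formyl-2-methoxyphenoxy reads like 5-methyl-1H-benzimidazol-1-yl, although it has no five-membered aromatic ring. The step of a 1.5-fold higher number from compound 2 to compound 4 (0.18 log units; within the scatter) is also within the scatter, so the two phenoxy groups on this carbon, of different sizes, cannot be told apart here. The step of a 6.0-fold higher number from compound 1 to compound 4 (0.78 log units; beyond the scatter) lies beyond the scatter, which shows that the number of compound 1 with its 2-chloro-1H-benzimidazol-1-yl group stands apart from this phenoxy group as well as from the 5-methyl benzimidazole.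

No measurement given here explains these numbers. On these data alone, it remains open whether a carboxylic acid or an amine in place of the formyl group on this phenoxy group would move the number beyond the scatter.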